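This account rests on a few compounds, and the source may have more. Where it says the series, first, only, none or still open, it means among the compounds named here.

Series notes. Compound 3 `COc1ccc(C(=O)/C=C/c2cc(-c3cc(OC)c(OC)c(OC)c3)n[nH]2)cc1` stands second highest of the three numbers in a functional assay on U-251 cells (Homo sapiens) for cytotoxicity, read by sulforhodamine B assay, with a stated time of 48 h, tested at 100 uM; on this read-out higher numbers stand for a weaker effect at the one concentration tested and lower numbers for a stronger effect; in that assay compound 3 gives -25%. Nearest is compound 2 `COc1cc(-c2cc(/C=C/C(=O)c3ccc(Cl)c(Cl)c3)[nH]n2)cc(OC)c1OC`, which gives -5% in this assay, and furthest is compound 1 `COc1ccc(-c2cc(/C=C/C(=O)c3ccc(OC)c(OC)c3)[nH]n2)cc1`, which gives -100% in this assay. The unmeasured compound 4 `COc1cc(-c2cc(/C=C/C(=O)c3ccc(F)c(F)c3)[nH]n2)cc(OC)c1OC` carries the change (3,4-difluorophenyl in place of 4-methoxyphenyl on a carbonyl carbon). Among the measured compounds shown here, the single step that bears on it is a number 20 percentage points lower from compound 2 to compound 3 (beyond the scatter); the present change runs the other way round, with fluorine in place of chlorine on the entering ring, so an upward step of roughly that size toward a weaker effect is expected in this assay, with added uncertainty from the different halogen. Compound 4 is therefore estimated at -10%, within -35% to 15%, an expected step of a number 15 percentage points higher from compound 3 to compound 4 (beyond the scatter).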

Compound 4, a percentage reported as activity, at one concentration (the size of the read-out at that concentration, not a potency): -29%
Estimate against measurement, compound 4: 19 percentage points above; measured number inside the range.
By their numbers in this assay, from the lowest: compound 1; then compounds 4 and 3 (each within the scatter of the next); then compound 2.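

In this assay the exchange on the carbonyl carbon gives a number 4 percentage points lower from compound 3 to compound 4 (within the scatter) and so does not separate 3,4-difluorophenyl from 4-methoxyphenyl. Exchanging one halogen for the other gives a number 24 percentage points lower from compound 2 to compound 4 (beyond the scatter) in the same direction as a number 20 percentage points lower from compound 2 to compound 3 (beyond the scatter) and so sets 3,4-dichlorophenyl apart from both other groups at this place. Nothing measured here accounts for these steps.

Open, on these data alone, is whether an amine or a carboxylic acid on the carbonyl carbon would leave the number near those of compound 3 and compound 4. Compound 1 differs from these compounds in more than one place, so it gives no reading of this change.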